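Benzylsulfanyl Swap on a Weakly Active Nucleotide Core

The source may hold more compounds than are shown below. What is called first, only, known or untested is meant among the compounds shown, and "the series" means these compounds.

Compound 1: `CNc1nc(=O)ccn1[C@@H]1O[C@H](COP(=O)(O)O)[C@@H](O)[C@H]1O` — > 100000 nM
Compound 2: `COc1nc(=O)ccn1[C@@H]1O[C@H](COP(=O)(O)OP(=O)(O)O)[C@@H](O)[C@H]1O` — 907 nM

In an in vitro functional assay on 1321-N1 cells for agonist activity at P2Y purinoceptor 2 (Homo sapiens), read by scintillation proximity assay and inositol phosphate accumulation (a lower number here means that less compound is needed, a higher number that more compound is needed for the effect), compound 1 gives > 100000 nM, which is a limit of the assay and not a number. Among the compounds with values here, compound 2, `COc1nc(=O)ccn1[C@@H]1O[C@H](COP(=O)(O)OP(=O)(O)O)[C@@H](O)[C@H]1O`, gives 907 nM in this assay; it differs from compound 1 in more than one place, so no single step links the two. All that is known of compound 1 is the limit of > 100000 nM in this assay, at which 1 of the 2 values shown sits.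

Compound 3, `O=c1ccn([C@@H]2O[C@H](COP(=O)(O)O)[C@@H](O)[C@H]2O)c(SCc2ccccc2)n1`, arises from compound 1 by benzylsulfanyl in place of methylamino on an aromatic carbon. Within the data shown here, no measured step covers a change of this kind, so its direction in this assay is open. The expected step of an at least 1.6-fold lower number from compound 1 to compound 3 (0.22 log units; that floor lies within the scatter) is likely small, possibly not beyond the scatter. Compound 3 is therefore estimated at 60000 nM, with a range from 10000 nM to 300000 nM, and a limit remains a real possibility.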

Compound 3, half-maximal effective concentration: >= 100000 nM
Compound 3 ended at the assay's limit (the forecaster's own chance of this, stated with the estimate: 60%); middle value at least 1.6-fold (0.22 log units) away from the limit.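

In this assay compound 1 gives > 100000 nM, which is a limit and not a number. Within the data shown here, compound 3 gives >= 100000 nM, also a limit, so no step between compound 1 and compound 3 can be read. Going by these compounds, whether benzylsulfanyl in place of methylamino changes the true value, in either direction, stays open.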